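Swapping the Carboxyphenyl Group in Compound 2

The source may report more compounds than this note shows. Statements on the series, on what has been measured and on what is new or still open speak of the compounds shown alone.

compound 1 `Cc1cc(C(=O)O)ccc1OCCCCOc1ccc(C(=O)CC(C)C)c(O)c1C`: 41%
compound 2 `Cc1c(OCCCCOc2cccc(C(=O)O)c2)ccc(C(=O)CC2CCCC2)c1O`: 55%

Within the data shown here, both compounds have been tested in an ADME assay (liver) for metabolic stability, with Liver microsome (Rattus norvegicus) as the target, read by LC-MS, using microsomes and NADPH, with stated times of 5 min and 60 min, tested at 4 uM; a higher number here means that more of the compound is left, a lower number that less of the compound is left. Compound 2 has the higher of the two numbers at 55%, while compound 1 gives 41%, a gap beyond the usual scatter of this kind of measurement.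

Compound 3 `Cc1cc(C(=O)O)ccc1OCCCCOc1ccc(C(=O)CC2CCCC2)c(O)c1C` has not been measured yet. It differs from compound 2 in one place: 4-carboxy-2-methylphenyl in place of 3-carboxyphenyl on an oxygen on a saturated carbon. Put simply, 4-carboxy-2-methylphenyl stands in place of 3-carboxyphenyl on an oxygen on a saturated carbon.

Among the measured compounds shown here, no two measured compounds differ in just one place, so no measured step can serve as a guide, and the size of this change is uncertain. For the measured compounds named here, the only other number available, 41% for compound 1, lies lower, so the expectation leans slightly downward. The expected change is a number 7 percentage points lower from compound 2 to compound 3 (within the scatter), a modest fall that may well stay within the scatter. For compound 3 the estimated value is 48%, with an expected range from 30% to 66%.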

Compound 3, percent of the compound remaining: 59%
Estimate against measurement, compound 3: 11 percentage points below, and the stated range covers the measured number.
By their numbers in this assay, from the lowest: compound 1; then compounds 2 and 3 (each within the scatter of the next).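

In this assay, putting 4-carboxy-2-methylphenyl in place of 3-carboxyphenyl on an oxygen on a saturated carbon gives a number 4 percentage points higher from compound 2 to compound 3 (within the scatter), so at this place the two aromatic groups cannot be told apart in this read-out. Compound 3 also provides the first single change at the other end of the molecule: cyclopentyl in place of isopropyl on a saturated chain carbon bound to a carbonyl carbon gives a number 18 percentage points higher from compound 1 to compound 3 (beyond the scatter), so among these three compounds the clear shift in the number goes with this change and not with the aromatic group. Nothing at hand gives a reason for either step.

As far as these compounds go, each change is seen only once, and the swap of aromatic groups alters both the place of the carboxy group and the presence of a methyl group, so the share of each remains open. From the compounds shown here alone, how a cyclohexyl group or a longer chain would fare in place of cyclopentyl, or an amide in place of the carboxylic acid, also remains open.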